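Gastric inhibition series: ester analogue of the pyridazinone

The source may report more compounds than this note shows. Statements on the series, on what has been measured and on what is new or still open speak of the compounds shown alone.

Measured so far:
compound 1 `NC(=O)CCn1nc(-c2ccccc2)ccc1=O` — -2.8%
compound 2 `N=C(S)CCCCCCn1nc(-c2ccccc2)ccc1=O` — 33.9%

For the measured compounds named here, in a functional assay on the whole organism (stomach) for inhibition, with Rattus norvegicus as the target, at a dose of 100 mg/kg by the intraduodenal route (on this read-out higher numbers stand for more inhibition at the one dose given (going by the name of the read-out) and lower numbers for less inhibition), compound 2 stands highest of the two numbers known; its nearest neighbour is compound 1, lower by a number 36.7 percentage points higher from compound 1 to compound 2 (beyond the scatter), a step beyond the scatter. Compound 3 `CCOC(=O)CCn1nc(-c2ccccc2)ccc1=O` is not yet measured. It differs from compound 2 by a group of 5 heavy atoms (3 carbon, 2 oxygen; no ring) in place of a group of 7 heavy atoms (5 carbon, 1 nitrogen, 1 sulfur; no ring), on a saturated chain carbon, two bonds along the chain from an aromatic nitrogen. Going by the values given here, the only step known is the one from compound 1 to compound 2, a number 36.7 percentage points higher from compound 1 to compound 2 (beyond the scatter), which went with the entry of the group that now leaves again. Compound 3 carries ethoxycarbonyl on the same chain position where compound 1 carries its three-atom group, so in this assay compound 3 is expected to sit nearer compound 1 than compound 2, that is a fall of a number 27.9 percentage points lower from compound 2 to compound 3 (beyond the scatter). Compound 3 is estimated at 6%, within -10% to 24%.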

Compound 3, a percentage reported as inhibition, in the whole organism at one dose (the size of the read-out at that dose, not a potency): 6.3%
Beside the measured number, compound 3's estimate is 0.3 percentage points below it; the measured number falls inside the stated range.
By their numbers in this assay, from the lowest: compounds 1 and 3 (each within the scatter of the next); then compound 2.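

In this assay, replacing the group of compound 2 with ethoxycarbonyl on a saturated chain carbon, two bonds along the chain from an aromatic nitrogen, gives a number 27.6 percentage points lower from compound 2 to compound 3 (beyond the scatter), so the level of compound 2 does not carry over to this ester. Ethoxy in place of amino on a carbonyl carbon gives a number 9.1 percentage points higher from compound 1 to compound 3 (within the scatter), so this read-out does not separate the ester from the amide, and both remain beyond the scatter from compound 2. No measurement at hand accounts for these differences.

As far as these compounds go, it remains open whether the higher number of compound 2 goes with its longer chain or with its sulfur-bearing end group. Also open, from the compounds shown here alone, is how a carboxylic acid or an amine at this position would read.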